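This account rests on a few compounds, and the source may have more. Where it says the series, first, only, none or still open, it means among the compounds named here.

Compound 1 `Cc1cc(=O)c2c(O)cc(O)c([C@H]3CCN(C)C[C@H]3OC(=O)c3ccco3)c2o1`: 22%
Compound 2 `Cc1oc2c([C@H]3CCN(C)C[C@H]3O)c(O)cc(O)c2c(=O)c1C(O)c1cccc(Cl)c1`: 22%

In a functional assay on HL-60 cells (Homo sapiens) for inhibition, read by MTT assay, with a stated time of 48 h, tested at 10 uM (on this read-out lower numbers stand for less inhibition of growth and higher numbers for more inhibition of growth at the one concentration tested), compound 2 gives 22%, level with compound 1 at 22%. Compound 3 `Cc1oc2c([C@H]3CCN(C)C[C@H]3O)c(O)cc(O)c2c(=O)c1C(O)c1cc(F)cc(F)c1` has not yet been measured. It carries 3,5-difluorophenyl in place of 3-chlorophenyl on a saturated chain carbon bound to an aromatic carbon and an oxygen on a saturated carbon. For the measured compounds named here, no measured pair shows what this swap does, so no change beyond the scatter is expected in this assay, in either direction. The estimated step is a number 2 percentage points higher from compound 2 to compound 3 (within the scatter). For compound 3, the expected value is 24%, with an estimated range of 8% to 45%.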

Compound 3, percent growth inhibition at one concentration: 30%
Compound 3: middle estimate off by 6 percentage points, on the low side, within the range that was stated.
By their numbers in this assay, from the lowest: compounds 1, 2 and 3 (each within the scatter of the next).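

In this assay, for the compounds shown here, putting 3,5-difluorophenyl in place of 3-chlorophenyl on a saturated chain carbon bound to an aromatic carbon and an oxygen on a saturated carbon gives a number 8 percentage points higher from compound 2 to compound 3 (within the scatter), the first direct reading of a change at this position. At this one concentration, this exchange of one halogen-bearing phenyl ring for another therefore makes no difference beyond the scatter. Nothing available gives a reason for the small step.

On these data alone, whether a plain phenyl, a pyridine ring or a longer alkyl chain at this position would shift growth inhibition beyond the scatter remains open.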